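Thiourea series: tolerated concentration on hamster kidney cells

The compounds below may be only part of what the source reports. "The series", "measured", "known", "first", "only" and "open" are said of these compounds alone.

Compound 1 `CC[C@H]1CC[C@H](c2ccc(NC(=S)Nc3cccc(C(F)(F)F)c3)cc2)CC1` holds the highest of the two numbers obtained so far, giving 10000 nM in an ADME assay on BHK cells (Mesocricetus auratus) for cytotoxicity, read by MTT assay, with a stated time of 96 h; a lower number here means that less compound is tolerated, a higher number that more compound is tolerated. Compound 2 `O=C(NC(=S)Nc1cccc(C(F)(F)F)c1)[C@H]1C[C@@H]2CC[C@H]1C2` gives 9600 nM in this assay; the two numbers lie within the scatter of each other, so nothing separates them. Compound 3 `O=[N+]([O-])c1ccc(NC(=S)Nc2cccc(C(F)(F)F)c2)cc1` awaits measurement and differs from compound 1 by nitro in place of 4-ethylcyclohexyl on an aromatic carbon. For the measured compounds named here, no step between measured compounds is available, so the size of this change is open; in this assay a step no larger than the scatter, in either direction, is expected, which corresponds to a 1.1-fold lower number from compound 1 to compound 3 (0.05 log units; within the scatter). Compound 3 is therefore estimated at 9000 nM, with a range from 3000 nM to 30000 nM.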

Compound 3, half-maximal cytotoxic concentration: 9500 nM
Beside the measured number, compound 3's estimate is 1.1-fold (0.02 log units) below it, and the stated range covers the measured number.
By their numbers in this assay, from the lowest: compounds 3, 2 and 1 (each within the scatter of the next).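

In this assay, for the compounds shown here, nitro in place of 4-ethylcyclohexyl on this aromatic carbon gives a 1.1-fold lower number from compound 1 to compound 3 (0.02 log units; within the scatter) and provides the first readable step. At this position, para to a large group, a substituent with a non-aromatic ring and one with no ring therefore fall within the scatter of each other. No measured evidence bears on this result.

On these data alone, whether an amine or a carboxylic acid here would also stay within the scatter remains open. The compounds shown include no group at this position that moves the number beyond the scatter.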